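The compounds below may be only part of what the source reports. "The series", "measured", "known", "first", "only" and "open" are said of these compounds alone.

Measured compounds:
Compound 1, `CS(=O)(=O)c1ccc(-c2cc(C(=O)N[C@H]3CCCNC3)c(NC(N)=O)s2)cc1`: 200 nM
Compound 2, `Cc1ccc(-c2cc(C(=O)N[C@H]3CCCNC3)c(NC(N)=O)s2)cc1`: 70 nM
Compound 3, `CN(C)C(=O)c1ccc(-c2cc(C(=O)N[C@H]3CCCNC3)c(NC(N)=O)s2)cc1`: 320 nM

In a functional assay on HT-29 cells (Homo sapiens) (a higher number here means that more compound is needed for the effect, a lower number that less compound is needed), compound 3 gives the highest of the three numbers. Its nearest neighbour is compound 1, with a 1.6-fold higher number from compound 1 to compound 3 (0.20 log units; within the scatter), a gap that is within the scatter; its furthest is compound 2, with a 4.6-fold higher number from compound 2 to compound 3 (0.66 log units; beyond the scatter), a gap that is beyond it. Within the data shown here, the series also contains a 2.9-fold lower number from compound 1 to compound 2 (0.46 log units; beyond the scatter), the one clearly resolved change among the three.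

Compound 4, `CNC(=O)c1ccc(-c2cc(C(=O)N[C@H]3CCCNC3)c(NC(N)=O)s2)cc1`, has not yet been measured in this assay. It differs from compound 3 by hydrogen in place of methyl on an amide-type nitrogen. Among the measured compounds shown here, none of the measured steps touches that nitrogen: every step in the set swaps the whole group on the aromatic carbon, and the shortest of them, from compound 1 to compound 3, stays within the scatter. For the measured compounds named here, there is thus no measured step that bears on removing one methyl from the dimethylcarbamoyl. On that basis the expected step of a 1.1-fold lower number from compound 3 to compound 4 (0.06 log units; within the scatter) is small, not beyond the scatter, with no direction favoured. Compound 4 is therefore expected to give about 280 nM in this assay, within a range from 120 nM to 700 nM.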

Compound 4, half-maximal effective concentration: 4300 nM
Estimate against measurement, compound 4: 15-fold (1.19 log units) below; the measured number lies above the stated range.
By their numbers in this assay, from the lowest: compound 2; then compounds 1 and 3 (each within the scatter of the next); then compound 4.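

In this assay, the single methyl on the amide-type nitrogen carries far more weight than the earlier swaps of the whole group suggested: the dimethylcarbamoyl compound had stayed within the scatter of the methylsulfonyl compound (a 1.6-fold higher number from compound 1 to compound 3 (0.20 log units; within the scatter)), yet taking one methyl away gives a 13-fold higher number from compound 3 to compound 4 (1.13 log units; beyond the scatter). The methylcarbamoyl group also sets compound 4 clearly apart from both other compounds, with a 22-fold higher number from compound 1 to compound 4 (1.33 log units; beyond the scatter) and a 61-fold higher number from compound 2 to compound 4 (1.79 log units; beyond the scatter), so it gives the highest number of the four, and the aromatic carbon's substituent is shown to be sensitive to a change of one heavy atom. Nothing shown here accounts for the size of this step.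

The compounds shown leave open what the same nitrogen does with two hydrogens, as in a plain carbamoyl group, or with an ethyl or a longer chain in place of the remaining methyl. They also leave open whether a carboxylic acid or an amine on the aromatic carbon would fall nearer compound 2 or compound 4.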